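A few compounds are considered here, and "the series" means these few. Any claim that something is new, unique, unknown or untested is made for them only; others in the source may bear on it.

Measured in an assay on isolated protein for inhibition of protein kinase C zeta type (Homo sapiens), with stated times of 1 h and 2.5 min, tested at 30 uM; a higher number here means more inhibition at the concentration tested (going by the name of the read-out), a lower number less inhibition:
compound 1, `CCOC(=O)c1c(-c2ccc(OC)c(OC)c2)csc1N(C)C` – compound 1 gives 60%
compound 2, `COc1ccc(-c2csc(N)c2C(=O)OCc2ccccc2)cc1OC` – compound 2 gives 100%

Compound 2 stands highest of the two numbers in this assay; the nearest, compound 1, lies below it by a gap beyond the usual scatter. Among the measured compounds shown here, no pair of measured compounds differs in one place only, so no single step is on record and the gap between compound 1 and compound 2 cannot be tied to one change.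

Compound 3, `COc1ccc(-c2csc(N)c2C(=O)OCc2cccc(C#N)c2)cc1OC`, is not yet measured in this assay. It differs from compound 2 by cyano in place of hydrogen on an aromatic carbon, that is, benzyl becomes 3-cyanobenzyl. Since compound 2 gives 100%, which leaves little room upward, the expected step from compound 2 to compound 3 is a number 8 percentage points lower from compound 2 to compound 3 (within the scatter), at most a small decrease, or none beyond the scatter. Compound 3 is estimated at 92%, within 70% to 100%.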

Compound 3, a percentage reported as inhibition, at one concentration (the size of the read-out at that concentration, not a potency): 70%
Compound 3: middle estimate off by 22 percentage points, on the high side; the measured number falls inside the stated range.
By their numbers in this assay, from the lowest: compounds 1 and 3 (each within the scatter of the next); then compound 2.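

In this assay, among the compounds shown here, cyano in place of hydrogen on an aromatic carbon of the benzyl group, meta to a large group, gives a number 30 percentage points lower from compound 2 to compound 3 (beyond the scatter), the first single change on record. This aromatic carbon is therefore a place where a small substituent registers in the read-out, although compound 3 still gives 70% at the concentration tested, so inhibition is reduced but not lost. Nothing on hand accounts for the drop.

As far as these compounds go, it remains open whether the drop belongs to cyano itself or to any group placed on this carbon, a question that a methoxy group, a chlorine or an amine at the same carbon would address. Also open, from the compounds shown here alone, is how the same cyano group would read on the other carbons of the benzyl group.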